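Replacing the group on the nitrogen of compound 2

The source may report more compounds than this note shows. Statements on the series, on what has been measured and on what is new or still open speak of the compounds shown alone.

compound 1 (`COc1ccc(CS(=O)(=O)/C=C/c2c(OC)cc(OCCCC(=O)O)cc2OC)cc1N`) measured at (20000 nM)
compound 2 (`COC(=O)C(C)(C)Nc1cc(CS(=O)(=O)/C=C/c2c(OC)cc(OC)cc2OC)ccc1OC`) measured at (800 nM)

Both values come from a functional assay on K562 cells (Homo sapiens) for cytotoxicity, read by trypan blue exclusion, with a stated time of 96 h (a lower number here means a stronger inhibitor, a higher number a weaker inhibitor), and they lie apart by more than the usual scatter of repeat measurements. Compound 2 has the lower of the two numbers and is the stronger inhibitor of the pair, while compound 1 stands far higher at 20000 nM on this scale.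

Compound 3 (`COc1cc(OC)c(/C=C/S(=O)(=O)Cc2ccc(OC)c(NC(F)(F)C(=O)O)c2)c(OC)c1`) has not yet been measured. It differs from compound 2 in one place, with carboxy(difluoro)methyl in place of 1-(methoxycarbonyl)-1-methylethyl on a nitrogen on an aromatic ring. Within the data shown here, no measured pair shows this change directly, so any forecast is uncertain. The nearest hint is compound 1, which also carries a carboxy group and gives 20000 nM in this assay but differs from compound 3 in other ways too. On that limited evidence a modest rise in the number is expected, toward weaker inhibition, with an estimated 1.9-fold higher number from compound 2 to compound 3 (0.27 log units; within the scatter) as the step. For compound 3 the estimated value is 1500 nM with an expected range (200 nM to 10000 nM).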

Compound 3, half-maximal inhibitory concentration: 150 nM
The estimate for compound 3 lay 10-fold (1.00 log units) above the measured number; measured number outside the range, below it.
By their numbers in this assay, from the lowest: compound 3; then compound 2; then compound 1.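

In this assay, the group on the nitrogen on the aromatic ring proves to be a place where a change of substituent moves the number beyond the scatter, with a 5.3-fold lower number from compound 2 to compound 3 (0.73 log units; beyond the scatter) on going from 1-(methoxycarbonyl)-1-methylethyl to carboxy(difluoro)methyl. The earlier compounds shown here could not show this, since they offered no pair differing in one place, and compound 3 now shows that a substituent on this nitrogen can end in a carboxy group and still give a lower number than the methoxycarbonyl-bearing group of compound 2. The change is compound, however, as the two methyl groups give way to two fluorine atoms while the ester gives way to a free carboxy group, and nothing available explains why the number falls.

The compounds shown leave open whether the fall follows the fluorine atoms, the free carboxylic acid, or the two together, a question that carboxymethyl or the methyl ester of carboxy(difluoro)methyl on the same nitrogen would bear on directly. They also leave open how a longer chain between this nitrogen and the carboxylic acid would read.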